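The source may report more compounds than this note shows. Statements on the series, on what has been measured and on what is new or still open speak of the compounds shown alone.

Measured compounds:
compound 1 `O=c1ccoc(/C=C/c2ccccc2)c1`: in a functional assay on U-251 cells (Homo sapiens) for inhibition, read by sulforhodamine B assay, with a stated time of 48 h (a higher number here means a weaker inhibitor of growth, a lower number a stronger inhibitor of growth), compound 1 gives 285 uM
compound 2 `COc1ccc(/C=C/c2cc(=O)cco2)cc1`: in this assay compound 2 gives 278 uM
compound 3 `COc1ccc(/C=C/C2CC=CC(=O)N2)cc1`: in this assay compound 3 gives 981 uM

Compound 1 and compound 2 share a core and differ in one place: methoxy in place of hydrogen on an aromatic carbon. The step of a 1.0-fold lower number from compound 1 to compound 2 (0.01 log units; within the scatter) shows that this change left the growth-inhibiting concentration essentially unchanged between these two compounds.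

Compound 3 carries a different core; the difference between its core and the core of compound 1 is not broken down here. In this assay compound 3 gives the highest of the three numbers, and its gap to compound 1 and to compound 2 lies beyond the scatter in both cases.

Compound 4 `COc1ccc(/C=C/C2CC=CC(=O)N2)c(OC)c1` is yet to be measured. It differs from compound 3 by methoxy in place of hydrogen on an aromatic carbon. For the measured compounds named here, this is the same kind of change as the one from compound 1 to compound 2, but not the same: in the first case the methoxy enters para to a group of 9 heavy atoms, whereas in compound 4 it enters ortho to a group of 9 heavy atoms and meta to a methoxy group. Going by the values given here, since the only precedent, a 1.0-fold lower number from compound 1 to compound 2 (0.01 log units; within the scatter), was within the scatter, the expected step is a 1.1-fold lower number from compound 3 to compound 4 (0.04 log units; within the scatter), with little confidence given the different core and the different place. Compound 4 is therefore expected to give about 900 uM in this assay, within a range from 350 uM to 2300 uM.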

Compound 4, concentration for growth inhibition (reported as GI): > 964 uM
Compound 4: no number, only a limit; the forecaster's own chance of this, stated with the estimate: 20%; middle value at least 1.0-fold (0.02 log units) from the limit.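

In this assay compound 4 gives > 964 uM, which is a limit of the assay and not a number. The step from compound 3 to compound 4 therefore cannot be read. The compounds shown leave open whether methoxy in place of hydrogen on this aromatic carbon of compound 3 changes the growth-inhibiting concentration at all and, if it does, in which direction.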